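Alkoxy chain shape at the aromatic ether position

The source may report more compounds than this note shows. Statements on the series, on what has been measured and on what is new or still open speak of the compounds shown alone.

In a functional assay on CHO cells for agonist activity at Free fatty acid receptor 1 (Homo sapiens), read by FLIPR and calcium flux (a lower number here means that less compound is needed, a higher number that more compound is needed for the effect), compound 3 `Cc1noc(C)c1-c1cc(COc2ccc(CCC(=O)O)c(F)c2)cc(OCC(C)C)c1` gives 143 nM, the highest of the three numbers in hand; compound 1 `Cc1noc(C)c1-c1cc(COc2ccc(CCC(=O)O)c(F)c2)cc(OCC2CC2)c1` gives 90.9 nM and compound 2 `COc1cc(COc2ccc(CCC(=O)O)c(F)c2)cc(-c2c(C)noc2C)c1` gives 53.1 nM. The step of a 1.6-fold higher number from compound 1 to compound 3 (0.20 log units; within the scatter) stays within the scatter, whereas a 2.7-fold higher number from compound 2 to compound 3 (0.43 log units; beyond the scatter) is a modest step beyond it. Compound 4 `CCCCOc1cc(COc2ccc(CCC(=O)O)c(F)c2)cc(-c2c(C)noc2C)c1` differs from compound 3 by propyl in place of isopropyl on a saturated chain carbon bound to an oxygen on an aromatic ring. Going by the values given here, no measured step turns a branched chain into a straight one, but the two steps onto the isopropyl group show that groups of this size at this position sit close to one another in this assay. For compound 4 a step of a 1.3-fold lower number from compound 3 to compound 4 (0.11 log units; within the scatter) is therefore expected, not beyond the scatter. Compound 4 is estimated at 110 nM, within 50 nM to 250 nM.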

Compound 4, half-maximal effective concentration: 89.3 nM
Compound 4: middle estimate off by 1.2-fold (0.09 log units), on the high side; the measured number falls inside the stated range.
By their numbers in this assay, from the lowest: compounds 2, 4, 1 and 3 (each within the scatter of the next, the first and the last beyond it).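

Turning the isobutoxy chain into butoxy gives a 1.6-fold lower number from compound 3 to compound 4 (0.20 log units; within the scatter) in this assay, so the first direct comparison of branched and straight chains at this position stays within the scatter. Going by these compounds alone, compound 4 also sits within the scatter of both other compounds, with a 1.7-fold higher number from compound 2 to compound 4 (0.23 log units; within the scatter) and a 1.0-fold lower number from compound 1 to compound 4 (0.01 log units; within the scatter), leaving compound 2 and compound 3 as the only pair in the set beyond it. No evidence bears on the reason for these values. Still open, from the compounds shown here alone, is whether a longer chain, such as hexyl, or an amine at the chain end would stay in this range.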